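This account rests on a few compounds, and the source may have more. Where it says the series, first, only, none or still open, it means among the compounds named here.

Compound 1 `Nc1nc2ccnc(-c3cccc(C(F)(F)F)c3)n2n1`: 2200 nM; 2200 nM (2 entries) (two entries)
Compound 2 `Nc1nc2ccnc(-c3cccc(C(Cl)Cl)c3)n2n1`: 1000 nM (one entry)
Compound 3 `Nc1nc2ccnc(-c3cccc(Br)c3)n2n1`: 3700 nM; 3700 nM (2 entries) (two entries)

These three values come from a functional assay (Homo sapiens); a higher number here means a weaker inhibitor, a lower number a stronger inhibitor. Compound 2 stands on a single entry, and its number lies below those of the other two compounds. The two entries of compound 1 agree with each other, as do the two entries of compound 3. The values of compound 1 and compound 3 lie close together.

The next compound to be tested is compound 4 `Nc1nc2ccnc(-c3cccc(Cl)c3)n2n1`, which has not yet been measured. Relative to compound 2, it carries chloro in place of dichloromethyl on an aromatic carbon. For the measured compounds named here, no measured pair in this small set isolates such a change, so the expectation rests on a limited comparison. The nearest guide is compound 3 at 3700 nM; 3700 nM (2 entries), which carries bromo where compound 4 carries chloro. In this assay, a move to a higher number, and so to a weaker inhibitor, is therefore expected, probably somewhat beyond the usual scatter. The expected change is estimated as a 3.0-fold higher number from compound 2 to compound 4 (0.48 log units; beyond the scatter). For compound 4 the estimated value is 3000 nM, with an expected range from 1300 nM to 6500 nM.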

Compound 4, half-maximal inhibitory concentration: 4300 nM
For compound 4 the middle estimate is 1.4-fold (0.16 log units) below the measured one; the range from low to high includes it.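

In this assay, chloro in place of dichloromethyl on this aromatic carbon, meta to a large group, gives a 4.3-fold higher number from compound 2 to compound 4 (0.63 log units; beyond the scatter) and so a weaker inhibitor, which makes this the first single-place comparison showing that the position responds to the group it carries. For the compounds shown here, the heavy atoms of the group fall from 3 to 1 in this step, and the change in potency lies beyond the usual scatter, although the lower end of the comparison rests on the single numeric entry of compound 2. Compound 3 at 3700 nM; 3700 nM (2 entries) and compound 4 at 4300 nM have values that lie close together, and nothing available bears on why the step from dichloromethyl to chloro has this size.

The compounds shown carry only halogens or halogen-bearing carbon groups at this position, so they leave open how an amine, a carboxylic acid or a longer chain would read there. They also leave open whether chloromethyl, with a single chlorine on the carbon, would stand nearer to dichloromethyl or to chloro.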